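This account rests on a few compounds, and the source may have more. Where it says the series, first, only, none or still open, it means among the compounds named here.

Working notes on the series. All three measured compounds share one core and an ether-linked saturated chain: compound 1 `NCCCCCCOc1ccc2c(=O)c(-c3ccc(O)cc3)coc2c1` ends that chain in an amine, compound 2 `O=C(O)CCCCCCCOc1ccc2c(=O)c(-c3ccc(O)cc3)coc2c1` and compound 3 `O=C(O)CCCCCCCCCOc1ccc2c(=O)c(-c3ccc(O)cc3)coc2c1` in a carboxylic acid. In an assay (Cricetulus griseus) for inhibition of aldehyde dehydrogenase, mitochondrial (Homo sapiens) (on this read-out higher numbers stand for weaker inhibition and lower numbers for stronger inhibition), compound 1 gives 100 nM, compound 2 gives 40 nM and compound 3 gives 50 nM. Compound 3 stands second highest of the three numbers, and both its gaps, to compound 2 and to compound 1, lie within the scatter.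

Compound 4 `CCCCCCOc1ccc2c(=O)c(-c3ccc(O)cc3)coc2c1` differs from compound 3 by hydrogen in place of 3-carboxypropyl on a saturated chain carbon, six bonds along the chain from an oxygen on an aromatic ring. Among the measured compounds shown here, no measured step removes the terminal group altogether. The nearest comparisons, a 2.5-fold lower number from compound 1 to compound 2 (0.40 log units; beyond the scatter) and a 2.0-fold lower number from compound 1 to compound 3 (0.30 log units; within the scatter), swap one terminal polar group for another, while a 1.3-fold higher number from compound 2 to compound 3 (0.10 log units; within the scatter) lengthens the acid chain with no effect beyond the scatter. For the measured compounds named here, on that basis the chain end appears to shift the number only modestly, so for compound 4 a small rise is expected, a 1.6-fold higher number from compound 3 to compound 4 (0.20 log units; within the scatter), with wide uncertainty: no measured compound carries a bare chain. Compound 4 is estimated at 80 nM in this assay, between 25 nM and 250 nM.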

Compound 4, half-maximal inhibitory concentration: 1500 nM
The estimate for compound 4 lay 19-fold (1.27 log units) below the measured number, and the stated range ends below it.
By their numbers in this assay, from the lowest: compounds 2, 3 and 1 (each within the scatter of the next, the first and the last beyond it); then compound 4.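

In this assay, removing the chain-end group altogether matters far more than exchanging one for another: a 30-fold higher number from compound 3 to compound 4 (1.48 log units; beyond the scatter), a 38-fold higher number from compound 2 to compound 4 (1.57 log units; beyond the scatter) and a 15-fold higher number from compound 1 to compound 4 (1.18 log units; beyond the scatter), all large and beyond the scatter. The step from the amine is the cleanest reading, since hydrogen replaces amino on the saturated chain carbon while the chain stays otherwise unchanged; the steps from the two acids also shorten the chain, yet they land at the same compound 4, so a terminal amine or carboxylic acid is what separates these compounds from the bare chain. Nothing available explains why the bare chain end fares so much worse.

As far as these compounds go, it remains open whether a hydroxyl or a primary amide at the chain end would behave like the amine and the acids. Also open, from the compounds shown here alone, is whether a longer chain with no terminal group would stay close to compound 4, which would separate chain length from the end group.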